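Two hydroxyls in place of fluorine and hydroxyl

The source may hold more compounds than are shown below. What is called first, only, known or untested is meant among the compounds shown, and "the series" means these compounds.

For the measured compounds named here, compound 2 `CN(C)CCn1cnnc1-c1cc(Oc2ccc(NC(=O)N/N=C/c3ccc(O)c(F)c3)cc2F)ccn1` stands at the higher of the two numbers measured so far: in a functional assay on HT-29 cells (Homo sapiens) for cytotoxicity, read by MTT assay, with a stated time of 72 h (on this read-out higher numbers stand for weaker inhibition and lower numbers for stronger inhibition), compound 2 gives 3310 nM. Going by the values given here, its only neighbour is compound 1 `CN(C)CCn1cnnc1-c1cc(Oc2ccc(NC(=O)N/N=C/c3c(O)ccc4ccccc34)cc2F)ccn1`, which in this assay gives 670 nM, and the step of a 4.9-fold higher number from compound 1 to compound 2 (0.69 log units; beyond the scatter) places compound 2 beyond the scatter from compound 1.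

Compound 3 `CN(C)CCn1cnnc1-c1cc(Oc2ccc(NC(=O)N/N=C/c3ccc(O)cc3O)cc2F)ccn1` differs from compound 2 in one place: 2,4-dihydroxyphenyl in place of 3-fluoro-4-hydroxyphenyl on a carbon with a double bond to nitrogen. Among the compounds with values here, the single measured step, from compound 1 to compound 2, exchanges 2-hydroxynaphthalen-1-yl for 3-fluoro-4-hydroxyphenyl on the same carbon, so it shows only that this assay answers to what sits on that carbon; it does not measure a fluorine leaving or a second hydroxyl entering. Within the data shown here, no measured pair speaks to the change into 2,4-dihydroxyphenyl directly. The step of a 1.3-fold lower number from compound 2 to compound 3 (0.12 log units; within the scatter) is therefore expected to stay within the scatter, with no direction that the data can support. Compound 3 is estimated at 2500 nM in this assay, with a range from 800 nM to 8000 nM, and the measurement will decide.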

Compound 3, half-maximal inhibitory concentration: 52600 nM
For compound 3 the middle estimate is 21-fold (1.32 log units) below the measured one; measured number above the stated range.
By their numbers in this assay, from the lowest: compound 1; then compound 2; then compound 3.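

In this assay, the carbon with a double bond to nitrogen proves far more sensitive than the first step suggested: 2,4-dihydroxyphenyl in place of 3-fluoro-4-hydroxyphenyl gives a 16-fold higher number from compound 2 to compound 3 (1.20 log units; beyond the scatter), even though the two groups have the same count of heavy atoms and each holds one six-membered aromatic ring of carbon only. Measured against the 2-hydroxynaphthalen-1-yl group, the change gives a 79-fold higher number from compound 1 to compound 3 (1.89 log units; beyond the scatter), a much wider spread than a 4.9-fold higher number from compound 1 to compound 2 (0.69 log units; beyond the scatter), and it makes compound 3 the weakest of the three, with every step between them beyond the scatter. The compounds shown therefore establish that a change within a single hydroxylated phenyl group can matter more here than the exchange of the naphthalene-bearing group for a phenyl-bearing one, but no available evidence bears on why this happens.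

Since fluorine leaves and a second hydroxyl enters in one step, the compounds shown cannot separate the part each change plays in the result. They also leave open how this assay would answer if a methoxy group or an amine stood on the phenyl ring in place of a hydroxyl.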